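A few compounds are considered here, and "the series" means these few. Any claim that something is new, unique, unknown or untested is made for them only; others in the source may bear on it.

Working notes on the series in a functional assay on isolated protein for inhibition of Glucose-dependent insulinotropic receptor (Rattus norvegicus), read by HTRF and cAMP accumulation; on this read-out higher numbers stand for larger maximal responses and lower numbers for smaller maximal responses.

Compound 1 `Cc1nc(S(C)(=O)=O)ccc1Oc1ncnc(OC2CCN(C(=O)O[C@@H](C)CF)CC2)c1F` is the reference point of this set; in this assay compound 1 gives 84%. Among the three measured numbers compound 1 stands second highest. The nearest value belongs to compound 2 `Cc1nc(S(C)(=O)=O)ccc1Oc1ncnc(OC2CCN(C(=O)O[C@H](C)C(F)(F)F)CC2)c1F`, which gives 85%; the step is a number 1 percentage points higher from compound 1 to compound 2 (within the scatter), the change being 1-(trifluoromethyl)ethyl in place of 1-(fluoromethyl)ethyl on an oxygen next to a carbonyl group. The furthest value belongs to compound 3 `Cc1nc(S(C)(=O)=O)ccc1Oc1ncnc(OC2CCN(C(=O)SC3CC3)CC2)c1F`, which gives 80%; the step is a number 4 percentage points lower from compound 1 to compound 3 (within the scatter), and the related step of a number 5 percentage points lower from compound 2 to compound 3 (within the scatter) likewise stays within the scatter. All three measured steps, two of them on the same carbonyl carbon, are small.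

Compound 4 `Cc1nc(S(C)(=O)=O)ccc1Oc1ncnc(OC2CCN(C(=O)C(C)(F)F)CC2)c1F` differs from compound 1 by a group of 4 heavy atoms (2 carbon, 2 fluorine; no ring) in place of a group of 5 heavy atoms (3 carbon, 1 oxygen, 1 fluorine; no ring), on a carbonyl carbon. For the measured compounds named here, the steps that bear on it, on the carbonyl carbon, were a number 4 percentage points lower from compound 1 to compound 3 (within the scatter) and a number 5 percentage points lower from compound 2 to compound 3 (within the scatter), neither beyond the scatter. No step beyond the scatter is therefore expected here either. For compound 4 the expected value is 83%, within a range of 73% to 93%. The expected step is a number 1 percentage points lower from compound 1 to compound 4 (within the scatter).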

Compound 4, largest response reached (reported as efficacy), in percent of the reference or control that the assay uses: 87%
Compound 4: middle estimate off by 4 percentage points, on the low side, within the range that was stated.
By their numbers in this assay, from the lowest: compounds 3, 1, 2 and 4 (each within the scatter of the next).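

In this assay the 1,1-difluoroethyl group on the carbonyl carbon, which has no hydrogen-bond acceptor where the group it replaces has one, gives a number 3 percentage points higher from compound 1 to compound 4 (within the scatter). The other two comparisons are a number 2 percentage points higher from compound 2 to compound 4 (within the scatter) and a number 7 percentage points higher from compound 3 to compound 4 (within the scatter), so this position now holds groups with oxygen, with sulfur and with neither on the carbonyl carbon, with no step beyond the scatter. No supporting evidence on the reason for this result is available.

From the compounds shown here alone, whether an amine, a carboxylic acid or a longer chain on this carbonyl carbon would give a step beyond the scatter stays open. Changes elsewhere on the shared core also stay open, as all four compounds differ only at this one place.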